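The compounds below may be only part of what the source reports. "The series", "measured", "known", "first", "only" and "open" are said of these compounds alone.

Measured in a functional assay on MDA-MB-231 cells (Homo sapiens) for inhibition, read by MTT assay, with a stated time of 72 h; a lower number here means a stronger inhibitor, a higher number a weaker inhibitor:
- Compound 1 `C[C@H](NC(=O)c1cc(Cl)ccc1OCCN)C(=O)Nc1ccc([N+](=O)[O-])cc1Cl`: > 10000 nM
- Compound 2 `CC[C@@H](C)[C@H](NC(=O)c1cc(Cl)ccc1OCCNC(=O)OC(C)(C)C)C(=O)Nc1ccc([N+](=O)[O-])cc1Cl`: 4020 nM

For the measured compounds named here, compound 2, at 4020 nM, holds the only actual number in this assay so far. The entry for compound 1 is a limit of the assay and not a number, so the two compounds cannot be ranked by a measured step.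

Compound 3 `CC[C@@H](C)[C@H](NC(=O)c1cc(Cl)ccc1OCCN)C(=O)Nc1ccc([N+](=O)[O-])cc1Cl` differs from compound 2 in one place: hydrogen in place of tert-butoxycarbonyl on an amine nitrogen. In words, hydrogen stands in place of tert-butoxycarbonyl on an amine nitrogen. Going by the values given here, no measured pair isolates this change.

Among the compounds with values here, compound 1 also carries the free amine, and the only guide to the change is its result. Compound 1 gives > 10000 nM, which is a limit. A modest move toward weaker inhibition in this assay is therefore expected, although this rests on a single compound, and the estimated size is a 2.0-fold higher number from compound 2 to compound 3 (0.30 log units; within the scatter). A result reported only as a limit would not be surprising. For compound 3 the estimate is 8000 nM, with an expected range of 2500 nM to 25000 nM.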

Compound 3, half-maximal inhibitory concentration: 6180 nM
Compound 3: middle estimate off by 1.3-fold (0.11 log units), on the high side, and the stated range covers the measured number.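

In this assay the exchange of tert-butoxycarbonyl for hydrogen on the amine nitrogen now has a measured pair, with a 1.5-fold higher number from compound 2 to compound 3 (0.19 log units; within the scatter), so at this position the two compounds cannot be told apart despite the loss of 7 heavy atoms. Compound 3 carries the free 2-aminoethyl group and still gives a number, which shows that this group alone does not take a compound of this series to the limit of the assay, and the other change, sec-butyl in place of methyl on the saturated chain carbon, reads as an at least 1.6-fold lower number from compound 1 to compound 3 (0.20 log units; that floor lies within the scatter). The entry for compound 1 is a limit and not a number, and that step is only a floor because of it: the limit of > 10000 nM in this assay, at which 1 of the 3 values shown sits.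

From the compounds shown here alone, the true size of the step from methyl to sec-butyl stays open, and so does whether tert-butoxycarbonyl on the amine nitrogen would make any difference with methyl on that chain carbon. Also open, going by these compounds, is how a carboxylic acid, an acetyl group on the amine nitrogen or a longer chain in place of 2-aminoethyl would read in this assay.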